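Trimming the side chain on the carbonyl carbon to amino

The source may hold more compounds than are shown below. What is called first, only, known or untested is meant among the compounds shown, and "the series" means these compounds.

In an ADME assay on CEM-SS cells (Homo sapiens) for cytotoxicity, read by XTT assay, with a stated time of 6 days (on this read-out higher numbers stand for lower toxicity in this test and lower numbers for higher toxicity in this test), compound 1 `CCCC(=O)OCSc1ccccc1C(=O)NC1(C(N)=O)CCCC1` reports only a limit, > 100 uM. Compound 2 `CCCC(=O)OCSc1ccccc1C(=O)NCCCNC(C)=O` gives 21.1 uM, and compound 3 `CCCC(=O)OCSc1ccccc1C(=O)N(C)CC(N)=O` gives 55.3 uM, the higher of the two actual numbers.

Compound 4 `CCCC(=O)OCSc1ccccc1C(N)=O` has not yet been measured. It carries amino in place of (carbamoylmethyl)(methyl)amino on a carbonyl carbon whose other neighbours are: aromatic carbon, (amino in place of (carbamoylmethyl)(methyl)amino on a carbonyl carbon).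

Among the compounds with values here, two measured steps bear on this change, and both alter the same substituent: an at least 4.7-fold lower number from compound 1 to compound 2 (0.67 log units; beyond the scatter), and a 2.6-fold higher number from compound 2 to compound 3 (0.42 log units; beyond the scatter). They run in opposite directions, and neither reduces the substituent to amino, so they give no firm direction. Compound 3 at 55.3 uM remains the natural anchor.

No step beyond the scatter is expected, with a slight lean towards a lower number, estimated as a 1.4-fold lower number from compound 3 to compound 4 (0.14 log units; within the scatter). Compound 4 is expected to give about 40 uM, with an estimated range from 15 uM to 100 uM.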

Compound 4, half-maximal toxic concentration: 12.4 uM
Estimate against measurement, compound 4: 3.2-fold (0.51 log units) above, outside the stated range (below it).
By their numbers in this assay, from the lowest: compounds 4 and 2 (each within the scatter of the next); then compound 3. At a limit, above all of these: compound 1.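

In this assay, the bare amide does not hold the number of the larger side chain: amino in place of (carbamoylmethyl)(methyl)amino on this carbonyl carbon gives a 4.5-fold lower number from compound 3 to compound 4 (0.65 log units; beyond the scatter). Removing the side chain does not always matter, however, as hydrogen in place of 3-acetamidopropyl on the amide-type nitrogen gives a 1.7-fold lower number from compound 2 to compound 4 (0.23 log units; within the scatter), so compound 2 goes against any rule that a side chain here raises the number. The third step, an at least 8.0-fold lower number from compound 1 to compound 4 (0.90 log units; beyond the scatter), starts from a limit of the assay and so gives only a minimum size: the limit of > 100 uM in this assay, at which 1 of the 4 values shown sits.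

The compounds shown leave open which part of (carbamoylmethyl)(methyl)amino goes with the higher number of compound 3. As far as these compounds go, how a small methylamino, a plain propylamino or a side chain ending in a carboxylic acid would stand at this position also remains open.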